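Swapping a Ring Hydrogen for a Pyrrolidinylethyl Chain

The source may hold more compounds than are shown below. What is called first, only, known or untested is meant among the compounds shown, and "the series" means these compounds.

Two compounds share one core. Compound 2 `O=C1c2c[n+]([O-])c3ccccc3c2C(=O)c2[nH]c3ccccc3c21` carries a bare hydrogen on its aromatic nitrogen; compound 1 `O=C1c2c[n+]([O-])c3ccccc3c2C(=O)c2c1c1ccccc1n2Cc1cn([C@H]2C[C@H](O)[C@@H](CO)O2)nn1` carries a large sugar-bearing group there. In a functional assay on A549 cells (Homo sapiens) for cytotoxicity, read by MTT assay, with a stated time of 72 h (a lower number here means a stronger inhibitor, a higher number a weaker inhibitor), compound 2 gives 320 nM, and compound 1 gives 350 nM, a gap that lies within the scatter. Compound 3 `O=C1c2c[n+]([O-])c3ccccc3c2C(=O)c2c1c1ccccc1n2CCN1CCCC1` is compound 2 with 2-(pyrrolidin-1-yl)ethyl in place of hydrogen on an aromatic nitrogen. Since compound 1 shows that a bulky group on this nitrogen leaves 350 nM essentially unchanged, the step of a 1.3-fold lower number from compound 2 to compound 3 (0.11 log units; within the scatter) is expected to be small or nil beyond the scatter. Compound 3 is therefore estimated at 250 nM, likely between 60 nM and 900 nM.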

Compound 3, half-maximal inhibitory concentration: 410 nM
Compound 3: middle estimate off by 1.6-fold (0.21 log units), on the low side; measured number inside the range.
By their numbers in this assay, from the lowest: compounds 2, 1 and 3 (each within the scatter of the next).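

In this assay placing 2-(pyrrolidin-1-yl)ethyl on the aromatic nitrogen gives a 1.3-fold higher number from compound 2 to compound 3 (0.11 log units; within the scatter) and so no change that can be told from the scatter. This position therefore takes a chain ending in a non-aromatic ring as well as the bare hydrogen, with the number staying in the same range. The data offer no measured explanation for this. Still open, as far as these compounds go, is whether a longer chain or a carboxylic acid on this nitrogen would move the number beyond the scatter.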